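The source may hold more compounds than are shown below. What is called first, only, known or untested is meant among the compounds shown, and "the series" means these compounds.

Measured in a physicochemical assay for lipophilicity, read by HPLC, measured as chromatographic lipophilicity; on this read-out higher numbers stand for higher lipophilicity and lower numbers for lower lipophilicity:
- Compound 1 `CCC/N=C1\S/C(=C\c2ccc(C(=O)OC)cc2)C(=O)N1c1ccccc1C`: > 4.4 (a limit of the assay, not a number)
- Compound 2 `CCC/N=C1\S/C(=C\c2ccc(C(=O)NCCO)cc2)C(=O)N1c1ccccc1C`: 2.3
- Compound 3 `CCC/N=C1\S/C(=C\c2ccc(C(=O)OCCCO)cc2)C(=O)N1c1ccccc1O`: 2.3

In this assay, compound 3 gives 2.3, the same reading at the digits shown as compound 2 at 2.3. Compound 1 sits at a limit, so its reading gives no exact position.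

The next compound, compound 4 `CCC/N=C1\S/C(=C\c2ccc(C(=O)OCC3COC(=O)O3)cc2)C(=O)N1c1ccccc1O`, has not yet been measured. It differs from compound 3 as follows: 2-oxo-1,3-dioxolan-4-yl in place of 2-hydroxyethyl on a saturated chain carbon bound to an oxygen next to a carbonyl group. In other words, 3-hydroxypropyl gives way to (2-oxo-1,3-dioxolan-4-yl)methyl on the ester oxygen.

For the measured compounds named here, no measured step makes this exchange. The nearest is the change from methoxy to (2-hydroxyethyl)amino on a carbonyl carbon, which reads a number at least 2.10 log units lower from compound 1 to compound 2 (beyond the scatter). From the compounds shown here alone, its full size is unknown because of the limit of > 4.4 in this assay, at which 1 of the 3 values shown sits. That step brings a hydroxyl-ended chain in and the reading falls, whereas here such a chain leaves, so the direction expected is upward. The carbonate ring that enters is rich in oxygen, however, and the ester stays in place, so only a small fraction of that size is expected.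

The expected change is a number 0.30 log units higher from compound 3 to compound 4 (within the scatter). For compound 4 the estimated value is 2.6, with an expected range of 1.9 to 3.4.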

Compound 4, distribution coefficient: 2.8
For compound 4 the middle estimate is 0.20 log units below the measured one; the range from low to high includes it.
By their numbers in this assay, from the lowest: compounds 2 and 3 (each within the scatter of the next); then compound 4. At a limit, above all of these: compound 1.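

In this assay, 2-oxo-1,3-dioxolan-4-yl in place of 2-hydroxyethyl, on a saturated chain carbon bound to an oxygen next to a carbonyl group, reads as a number 0.50 log units higher from compound 3 to compound 4 (beyond the scatter). This shows that the reading responds to a change at this place even with the ester kept, when a group with a five-membered non-aromatic ring and no hydrogen-bond donor replaces a chain end that carries one. Both ends of this step are numbers, so its size is known, whereas the earlier step out of compound 1 has no known full size, as compound 1 stands at a limit: the limit of > 4.4 in this assay, at which 1 of the 4 values shown sits.

From the compounds shown here alone, what stays open is which part of the exchange moves the reading, as the hydroxyl leaves and the ring enters in the same step; a simple propyl chain, or a chain ending in a methoxy group, an amine or a carboxylic acid, would help to separate the two. Going by these compounds, it is also open whether the same exchange would read alike on the amide-linked chain of compound 2.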